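The source may hold more compounds than are shown below. What is called first, only, known or untested is meant among the compounds shown, and "the series" means these compounds.

Two compounds here share one core and differ only in the small carbon groups attached to one of its rings. Compound 1 `CCc1c(C)sc2nc(C(C)C)c(/C=C/[C@@H](O)C[C@@H](O)CC(=O)O)c(-c3ccc(F)cc3)c12` carries an ethyl group on an aromatic carbon; in an in vivo functional assay on the whole organism for inhibition of 3-hydroxy-3-methylglutaryl-coenzyme A reductase (Rattus norvegicus), at a dose of 2 mg/kg by the oral route (on this read-out lower numbers stand for a weaker effect and higher numbers for a stronger effect at the one dose given), compound 1 gives 20.8%. Compound 2 `Cc1cc2c(-c3ccc(F)cc3)c(/C=C/[C@@H](O)C[C@@H](O)CC(=O)O)c(C(C)C)nc2s1` has a hydrogen in place of that ethyl, and in this assay compound 2 gives 34.2%. That single step, a number 13.4 percentage points higher from compound 1 to compound 2 (beyond the scatter), is the only measured one, and it favours the smaller group. For the measured compounds named here, on the two numbers known, compound 2 stands highest, with compound 1 a modest distance below it.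

Compound 3 `CC(C)c1cc2c(-c3ccc(F)cc3)c(/C=C/[C@@H](O)C[C@@H](O)CC(=O)O)c(C(C)C)nc2s1` is the next step from compound 2: isopropyl in place of methyl on an aromatic carbon. The measured step of a number 13.4 percentage points higher from compound 1 to compound 2 (beyond the scatter) concerns a different aromatic carbon and removed carbon rather than adding it, so it bears on this change only loosely, and it gives no sign that more carbon on this ring improves the read-out. Compound 3 is therefore expected to sit a little lower, the step being a number 9.2 percentage points lower from compound 2 to compound 3 (within the scatter), possibly within the scatter. The estimate for compound 3 in this assay is 25%, with a range from 8% to 45%.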

Compound 3, a percentage reported as inhibition, in the whole organism at one dose (the size of the read-out at that dose, not a potency): -19.3%
The estimate for compound 3 lay 44.3 percentage points above the measured number; the whole stated range lies above it.
By their numbers in this assay, from the lowest: compound 3; then compound 1; then compound 2.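

At the aromatic carbon next to the ring sulfur, replacing methyl (1 carbon) with isopropyl (3 carbons) brings a large loss, a number 53.5 percentage points lower from compound 2 to compound 3 (beyond the scatter), so this position is far less tolerant of a bigger carbon group than the first two compounds could reveal. In this assay compound 3 gives -19.3%, a number below zero, so the read-out does not merely shrink but changes sign, and at this one dose compound 3 shows no inhibition at all. Nothing measured here offers an explanation for this drop.

As far as these compounds go, with only methyl and isopropyl compared at this carbon, it remains open whether ethyl would fall between them, or whether the loss sets in only with the branched isopropyl, and how a hydrogen, a cyclopropyl ring or a methoxy group would behave in the same place. The read-out also reflects one oral dose in the whole animal rather than a potency, so these compounds leave open whether the same order would hold at other doses.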